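This account rests on a few compounds, and the source may have more. Where it says the series, first, only, none or still open, it means among the compounds named here.

Measured compounds:

compound 1 `O=C(CCCCC(S)CCS)Nc1ccccn1` gives 11.7%
compound 2 `O=C(CCCCC(S)CCS)Nc1ccc(Cl)cn1` gives 55.8%
compound 3 `CC(=O)SCCC(CCCCC(=O)Nc1ccccc1)SC(C)=O` gives 44.8%

All three numbers come from a functional assay on NCI-H460 cells (Homo sapiens) for inhibition, read by MTT assay, with a stated time of 24 h, tested at 100 ug/mL; on this read-out lower numbers stand for less inhibition of growth and higher numbers for more inhibition of growth at the one concentration tested. Compound 1 and compound 2 share one core; compound 3 has a different core with both thiols carrying an acetyl and the amide on a ring of carbon only. The difference between the two cores is not broken down here.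

Within the first pair the one change is chloro in place of hydrogen on an aromatic carbon. Its effect is a number 44.1 percentage points higher from compound 1 to compound 2 (beyond the scatter). Compound 3 stands between the two, beyond the scatter from each.

Compound 4 `CC(=O)SCCC(CCCCC(=O)Nc1ccccc1Cl)SC(C)=O` is not yet measured. It differs from compound 3 by chloro in place of hydrogen on an aromatic carbon. This is the same kind of change as that from compound 1 to compound 2, but not the same: in the measured pair the chloro sits on a six-membered aromatic ring with one nitrogen, two atoms from the ring nitrogen and para to a large group, while in compound 4 it sits on a six-membered aromatic ring of carbon only, ortho to a large group. Among the compounds with values here, with only one measured instance of the change, and that on a different core and at a different place, the step from compound 3 to compound 4 is expected to be a number 15.2 percentage points higher from compound 3 to compound 4 (beyond the scatter), smaller than the measured one, resting on compound 2 with 55.8% and on compound 3 with 44.8% as the starting point. For compound 4 the estimate in this assay is 60%, with a range from 40% to 80%.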

Compound 4, percent growth inhibition at one concentration: 15.2%
Beside the measured number, compound 4's estimate is 44.8 percentage points above it; the measured number lies below the stated range.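

In this assay, chloro in place of hydrogen on an aromatic carbon does not behave alike on the two cores: the same change on two cores in this assay, a number 44.1 percentage points higher (beyond the scatter) from compound 1 to compound 2 and a number 29.6 percentage points lower (beyond the scatter) from compound 3 to compound 4, 73.7 percentage points apart, beyond the scatter of two such steps.

On the core of compound 3, the reading is a number 29.6 percentage points lower from compound 3 to compound 4 (beyond the scatter), so in this series neither the direction nor the size of the step from the core of compound 1 can be carried over to the core of compound 3. Within the data shown here, this does not show what lies behind the opposite directions, since the two pairs differ at once in the ring that carries the chloro, in the place of the chloro, and in free thiols against thiols carrying an acetyl, and each core offers only one pair at one concentration.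

Still open, as far as these compounds go, is whether the opposite direction follows the ring, the place of the chloro or the acetyl groups, which a chloro on the ring of carbon only with both thiols free, or a chloro on the ring with one nitrogen with both thiols carrying an acetyl, could help separate. Also open, from the compounds shown here alone, is how a fluoro, a methyl or a methoxy in the same ortho place would read on the core of compound 3.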